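Swapping Phenyl for Allyl on the Ring Carbon

A few compounds are considered here, and "the series" means these few. Any claim that something is new, unique, unknown or untested is made for them only; others in the source may bear on it.

The three measured compounds share one core and differ only in the groups hung on it. In a functional assay on MCF7 cells (Homo sapiens) for inhibition, read by MTT assay, with a stated time of 48 h (a lower number here means a stronger inhibitor, a higher number a weaker inhibitor), compound 1 `C=C1C(=O)N(c2ccccc2)N(c2ccccc2)C1c1ccccc1` gives 4500 nM, the lowest of the three numbers. Compound 2 `C=C1C(=O)N(c2ccccc2)N(C)C1c1ccccc1` gives 84400 nM, and the step of a 19-fold higher number from compound 1 to compound 2 (1.27 log units; beyond the scatter) is large. Compound 3 `C=C1C(=O)N(c2ccccc2)N(C)C1C` gives 153000 nM, and the step of a 1.8-fold higher number from compound 2 to compound 3 (0.26 log units; within the scatter) is small. So replacing phenyl on the ring nitrogen cost much, while replacing phenyl on the saturated ring carbon changed little.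

Compound 4 `C=CCC1C(=C)C(=O)N(c2ccccc2)N1c1ccccc1` is not yet measured. It differs from compound 1 in one place: allyl in place of phenyl on a saturated ring carbon. For the measured compounds named here, the step that bears on this is the one from compound 2 to compound 3, which also replaced phenyl on that same saturated ring carbon and stayed within the scatter. Allyl is a three-carbon chain rather than a single carbon, but the available evidence gives no sign that this carbon is sensitive to what it carries. The step in this assay is therefore expected to be small, if anything towards a slightly higher number, and is estimated as a 1.8-fold higher number from compound 1 to compound 4 (0.25 log units; within the scatter). Compound 4 is expected to give about 8000 nM, with a range from 3000 nM to 25000 nM.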

Compound 4, half-maximal inhibitory concentration: 5100 nM
Beside the measured number, compound 4's estimate is 1.6-fold (0.20 log units) above it; low and high end bracket the measured number.
By their numbers in this assay, from the lowest: compounds 1 and 4 (each within the scatter of the next); then compounds 2 and 3 (each within the scatter of the next).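

Allyl in place of phenyl on the saturated ring carbon gives a 1.1-fold higher number from compound 1 to compound 4 (0.05 log units; within the scatter) in this assay, so here a three-carbon open chain with one double bond serves as well as a six-membered aromatic ring. For the compounds shown here, the only earlier change at this carbon came with methyl on the ring nitrogen, giving a 1.8-fold higher number from compound 2 to compound 3 (0.26 log units; within the scatter), and that left open whether the carbon would matter as little when the ring nitrogen carries phenyl, as it does in the compounds with the lowest numbers; within this pair, it does not show any effect either. Nothing measured alongside these compounds explains why the group on this carbon makes so little difference here.

Phenyl, methyl and allyl are all built from carbon and hydrogen alone, so it remains open whether this carbon would be equally undemanding of an amine, a carboxylic acid or a longer chain such as hexyl. The ring nitrogen, where methyl in place of phenyl gave a 19-fold higher number from compound 1 to compound 2 (1.27 log units; beyond the scatter), also remains to be explored with other groups, such as benzyl or ethyl.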